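A Phenoxy Swap on a Weak Inhibitor

A few compounds are considered here, and "the series" means these few. Any claim that something is new, unique, unknown or untested is made for them only; others in the source may bear on it.

- Compound 1 `CC(C)(C)OC(=O)N1CCC[C@H]1COCCCCCC/C=C/c1ccc(Oc2ccccc2)cc1` gives 63300 nM
- Compound 2 `Cc1ccc([S+]([O-])N2CCC[C@H]2COCCCCCC/C=C/c2ccc(-c3ccccc3)cc2)cc1` gives >= 100000 nM

In a functional assay on BXPC-3 cells (Homo sapiens) for inhibition, read by XTT assay, with a stated time of 72 h (a higher number here means a weaker inhibitor, a lower number a stronger inhibitor), compound 1 gives a measured number, 63300 nM in full. Compound 2 gives >= 100000 nM there, and this is a limit of the assay, not a number. Compound 3 `Cc1ccc([S+]([O-])N2CCC[C@H]2COCCCCCC/C=C/c2ccc(Oc3ccccc3)cc2)cc1` has the core of compound 2, with phenoxy in place of phenyl on an aromatic carbon. Going by the values given here, no measured pair shows this change alone. Compound 1 also carries phenoxy and gives 63300 nM in this assay, so a modest step toward a stronger inhibitor is expected (an at least 1.6-fold lower number from compound 2 to compound 3 (0.22 log units; that floor lies within the scatter)). Compound 3 is estimated at 60000 nM in this assay, with an expected range from 25000 nM to 100000 nM for the measurement.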

Compound 3, half-maximal inhibitory concentration: 50000 nM
Compound 3: middle estimate off by 1.2-fold (0.08 log units), on the high side; the measured number falls inside the stated range.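

In this assay compound 2 sits at a limit, not at a number: the limit of >= 100000 nM in this assay, at which 1 of the 3 values shown sits. Phenoxy in place of phenyl now has a pair that shows this change alone, and it reads as an at least 2.0-fold lower number from compound 2 to compound 3 (0.30 log units; that floor lies within the scatter), so its true size stays unknown and its floor does not clear the scatter. With phenoxy in both, the change of group on the amine nitrogen in a ring gives a 1.3-fold lower number from compound 1 to compound 3 (0.10 log units; within the scatter), so the two groups cannot be told apart here. As far as these compounds go, whether methoxy or an amine on that aromatic carbon would move the number stays open, as does the effect of a longer chain.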